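The source may hold more compounds than are shown below. What is called first, only, known or untested is meant among the compounds shown, and "the series" means these compounds.

Three compounds built on the same core have been examined in a functional assay on A549 cells (Homo sapiens) for cytotoxicity, read by MTT assay; on this read-out lower numbers stand for stronger inhibition and higher numbers for weaker inhibition. Compound 1 `CCOC(=O)c1oc2cc(OC)cc(OC)c2c1C` is recorded in this assay as "not active" (no number reported), with no number behind it. Compound 2 `COc1cc(OC)c2c(C)c(C(=O)NCc3ccccc3)oc2c1C(N)=O` gives 54800 nM in this assay. Compound 3 `CCOC(=O)c1oc2cc(OCc3ccccc3)cc(OCc3ccccc3)c2c1C` reaches only a limit of the assay, > 72000 nM, rather than a measured number. On the numbers shown, compound 3 stands at the limit of > 72000 nM in this assay, at which 1 of the 3 values shown sits, so its own strength is not pinned down, and the only compound with a real number, compound 2, is itself weak. Compound 4 `Cc1c(C=O)oc2cc(OCc3ccccc3)cc(OCc3ccccc3)c12` differs from compound 3 in one place: hydrogen in place of ethoxy on a carbonyl carbon, so that the ethoxycarbonyl group becomes a formyl group. Among the compounds with values here, no step between two measured compounds is available to guide this change, and the starting point is a limit. The expected step is an at least 1.0-fold lower number from compound 3 to compound 4 (0.01 log units; that floor lies within the scatter), nothing beyond the usual scatter, leaving compound 4 weak as well. For compound 4 the estimated value in this assay is 70000 nM, within a range from 25000 nM to 200000 nM, with a real chance that only a limit is again reported.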

Compound 4, half-maximal inhibitory concentration: > 80600 nM
Compound 4 gave a limit, no number; the forecaster's own chance of this, stated with the estimate: 55%; at least 1.1-fold (0.06 log units) between middle value and limit.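

Compound 3 and compound 4 are both recorded in this assay only as limits, and no step can be read between them. The compounds shown leave open how strong either compound really is, and whether going from ethoxycarbonyl to formyl changes the result at all.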